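This account rests on a few compounds, and the source may have more. Where it says the series, first, only, none or still open, it means among the compounds named here.

Measured compounds:
Compound 1, `CCCCNc1cnc(C(=O)NCc2ccccc2)cn1`, gives > 100000 nM in an ADME assay on HEL cells (Homo sapiens) for cytotoxicity, read by microscopy, with a stated time of 6 days; a lower number here means that less compound is tolerated, a higher number that more compound is tolerated; this is a limit of the assay, not a number.
Compound 2, `CCCCCCCCNc1cnc(C(=O)NCc2ccccc2)cn1`, gives 100000 nM in this assay.
Compound 3, `CCCCNc1cncc(C(=O)NCc2ccccc2)n1`, gives > 100000 nM in this assay; this too is a limit of the assay.

Compound 2 differs from compound 1 by butyl in place of hydrogen on a saturated chain carbon, four bonds along the chain from a nitrogen on an aromatic ring, and that step is a number no higher from compound 1 to compound 2 (the limit leaves the size open). Compound 3 has the same atoms as compound 1 joined differently; the difference between the two cores is not broken down here. Compound 4, `CCCCCCCCNc1cncc(C(=O)NCc2ccccc2)n1`, has not been measured yet. It differs from compound 3 by butyl in place of hydrogen on a saturated chain carbon, four bonds along the chain from a nitrogen on an aromatic ring, the same change as between compound 1 and compound 2. In this assay compound 4 is expected to give 100000 nM, estimated between 50000 nM and 200000 nM, because the same change gave a number no higher from compound 1 to compound 2 (the limit leaves the size open) and because of the limit of > 100000 nM in this assay, at which 2 of the 3 values shown sit. That means an expected step of a number no higher from compound 3 to compound 4 (the limit leaves the size open) from compound 3.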

Compound 4, minimum cytotoxic concentration: > 100000 nM
Compound 4: a limit, no number; the forecaster's own chance of this, stated with the estimate: 50%; the middle value sits exactly at the limit.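

Compound 3 and compound 4 are both reported only as limits of the assay, not as numbers, so the step between them cannot be read. As far as these compounds go, whether adding butyl changes the result in this assay on this core stays open.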